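Amine swap at the fused ring: compound 3 to compound 4

The source may hold more compounds than are shown below. What is called first, only, known or untested is meant among the compounds shown, and "the series" means these compounds.

In a functional assay on HCC1937 cells (Homo sapiens) for inhibition, read by MTT assay, with a stated time of 48 h (a lower number here means a stronger inhibitor, a higher number a weaker inhibitor), compound 3 `CCN1CCN(c2ncc3c(n2)CCN(C(=O)c2cc(Cc4n[nH]c(=O)c5ccccc45)ccc2F)C3)CC1` gives 137000 nM, the higher of the two numbers in hand; compound 2 `CN1CCN(c2ncc3c(n2)CCN(C(=O)c2cc(Cc4n[nH]c(=O)c5ccccc45)ccc2F)C3)CC1` gives 53400 nM, and compound 1 `O=C(c1cc(Cc2n[nH]c(=O)c3ccccc23)ccc1F)N1CCc2nc(Cl)ncc2C1` has "nd" (no result reported), that is, no result. For the measured compounds named here, the single measured step, a 2.6-fold higher number from compound 2 to compound 3 (0.41 log units; beyond the scatter), is the only guide. Compound 4 `O=C(c1cc(Cc2n[nH]c(=O)c3ccccc23)ccc1F)N1CCc2nc(N3CCCC3)ncc2C1` differs from compound 3 by pyrrolidin-1-yl in place of 4-ethylpiperazin-1-yl on an aromatic carbon. Going by the values given here, the ethyl that the measured step had added is removed here, which points to a partial reversal, but the ring itself also changes from six-membered to five-membered, and no measured pair covers that. For compound 4 the expected step is a 2.3-fold lower number from compound 3 to compound 4 (0.36 log units; beyond the scatter), downward and of a size comparable to the one measured. Compound 4 is therefore estimated at 60000 nM, within 20000 nM to 180000 nM.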

Compound 4, half-maximal inhibitory concentration: 7810 nM
Compound 4: the middle estimate sits 7.7-fold (0.89 log units) above what was measured; measured number outside the range, below it.
By their numbers in this assay, from the lowest: compound 4; then compound 2; then compound 3.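

In this assay, the group on this aromatic carbon moves the number further than the alkyl change on the piperazine, a 2.6-fold higher number from compound 2 to compound 3 (0.41 log units; beyond the scatter), does: pyrrolidin-1-yl gives an 18-fold lower number from compound 3 to compound 4 (1.24 log units; beyond the scatter) against 4-ethylpiperazin-1-yl and a 6.8-fold lower number from compound 2 to compound 4 (0.83 log units; beyond the scatter) against 4-methylpiperazin-1-yl. Compound 4 has the lowest number of the three, with both steps beyond the scatter. No measurement shown accounts for these steps.

This swap changes ring size and removes a ring nitrogen together, and the compounds shown do not separate the two. Piperidin-1-yl on the same aromatic carbon would keep the six-membered ring without the second nitrogen.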